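The source may hold more compounds than are shown below. What is called first, only, known or untested is meant among the compounds shown, and "the series" means these compounds.

Of the compounds shown here, three of a shared core have been measured in an ADME assay for permeability, using PAMPA, with a stated time of 30 min, at pH 7.4; on this read-out higher numbers stand for higher permeability and lower numbers for lower permeability. Compound 1 `COc1ccc(F)cc1CNCCCNc1ccnc2cc(C3CCCCC3)ccc12` gives 23 10^-6 cm/s, compound 2 `c1coc(CNCCCNc2ccnc3cc(C4CCCCC4)ccc23)c1` gives 23 10^-6 cm/s, and compound 3 `c1ccc(Cc2ccc3c(NCCCNCc4ccco4)ccnc3c2)cc1` gives 23 10^-6 cm/s. The step from compound 1 to compound 2, furan-2-yl in place of 5-fluoro-2-methoxyphenyl on a saturated chain carbon bound to an amine nitrogen, shows no change at the digits printed from compound 1 to compound 2 (within the scatter). The step from compound 2 to compound 3, benzyl in place of cyclohexyl on an aromatic carbon, shows no change at the digits printed from compound 2 to compound 3 (within the scatter). Compound 1 therefore stands level with compounds 2 and 3 on this read-out, with no difference among the three beyond the scatter.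

Compound 4 `COc1ccc(F)cc1CNCCCNc1ccnc2cc(Oc3cccc(N(C)C)c3)ccc12` has not yet been measured. It differs from compound 1 as follows: 3-(dimethylamino)phenoxy in place of cyclohexyl on an aromatic carbon. Among the compounds with values here, of the measured steps, the one from compound 2 to compound 3 bears most directly on it, as it also exchanges the cyclohexyl on the same aromatic carbon, and it showed no change at the digits printed from compound 2 to compound 3 (within the scatter). The step from compound 1 to compound 2 changes another part of the molecule and likewise showed no change at the digits printed from compound 1 to compound 2 (within the scatter). On this basis the step of a 1.3-fold lower number from compound 1 to compound 4 (0.11 log units; within the scatter) is expected to be small, most likely within the scatter, with a slight lean downward allowed by the wider range. Compound 4 is accordingly estimated at 18 10^-6 cm/s, between 9 10^-6 cm/s and 36 10^-6 cm/s.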

Compound 4, apparent permeability: 317 10^-6 cm/s
Compound 4: middle estimate off by 18-fold (1.25 log units), on the low side, and the stated range ends below it.
By their numbers in this assay, from the lowest: compounds 1, 2 and 3 (each within the scatter of the next); then compound 4.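

In this assay, the position on the aromatic carbon, meta to a fused ring and para to a fused ring, proves able to carry a large change: the exchange of cyclohexyl for 3-(dimethylamino)phenoxy gives a 14-fold higher number from compound 1 to compound 4 (1.14 log units; beyond the scatter), whereas the earlier exchange of cyclohexyl for benzyl at this same position gave no change at the digits printed from compound 2 to compound 3 (within the scatter) and so had suggested a position with little effect on this read-out. The two exchanges therefore do not behave alike, and the entering group here differs from cyclohexyl in its aromatic ring, its nitrogen and oxygen atoms, and its hydrogen-bond acceptors, so any of these may be involved. Nothing at hand accounts for the size of the step.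

The compounds shown leave open which part of the 3-(dimethylamino)phenoxy group carries the step, a question that a plain phenoxy group or a 3-(dimethylamino)phenyl group joined directly to the core would address. They also leave open whether the same exchange gives a step of similar size when the furan-2-yl side chain of compound 2 stands in place of the 5-fluoro-2-methoxyphenyl one.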